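Swapping the Aryl Group on Compound 3

The compounds below may be only part of what the source reports. "The series", "measured", "known", "first", "only" and "open" are said of these compounds alone.

In a functional assay on GBM1 cells (Homo sapiens) for antiproliferative activity, read by WST assay, with a stated time of 72 h (on this read-out lower numbers stand for stronger inhibition and higher numbers for weaker inhibition), compound 1 (`O=C(Nc1cccc(Cl)c1)Nc1cc2ncncc2cc1OCc1ccccc1Cl`) gives 2600 nM, compound 2 (`O=C(Nc1ccc(C(F)(F)F)cc1)Nc1cc2ncncc2cc1OCc1cccc(F)c1`) gives 3800 nM and compound 3 (`O=C(Nc1cccc(Cl)c1)Nc1cc2ncncc2cc1OCc1cccc(Cl)c1`) gives 3300 nM. Compound 3 thus stands within the scatter of both others. Compound 4 (`O=C(Nc1ccc(C(F)(F)F)cc1)Nc1cc2ncncc2cc1OCc1cccc(Cl)c1`) carries 4-(trifluoromethyl)phenyl in place of 3-chlorophenyl on an amide-type nitrogen. Going by the values given here, no measured step covers this change. Among the compounds with values here, the one step available, a 1.3-fold higher number from compound 1 to compound 3 (0.10 log units; within the scatter), lies within the scatter and concerns a different place. Compound 2, which already bears 4-(trifluoromethyl)phenyl, gives 3800 nM, within the scatter of compound 3. No step beyond the scatter is therefore expected in this assay. The expected step is a 1.1-fold higher number from compound 3 to compound 4 (0.04 log units; within the scatter). For compound 4 the estimated value is 3600 nM, with an expected range of 1800 nM to 7000 nM.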

Compound 4, half-maximal inhibitory concentration: 3400 nM
Compound 4: middle estimate off by 1.1-fold (0.02 log units), on the high side; the range from low to high includes it.
By their numbers in this assay, from the lowest: compounds 1, 3, 4 and 2 (each within the scatter of the next).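

In this assay, going by these compounds alone, 4-(trifluoromethyl)phenyl in place of 3-chlorophenyl on an amide-type nitrogen gives the first measured step at this place (a 1.0-fold higher number from compound 3 to compound 4 (0.01 log units; within the scatter)), and it lies within the scatter. Chloro in place of fluoro on an aromatic carbon, with 4-(trifluoromethyl)phenyl held fixed, also stays within the scatter (a 1.1-fold lower number from compound 2 to compound 4 (0.05 log units; within the scatter)). No evidence on hand bears on this result. From the compounds shown here alone, whether an amine or a carboxylic acid in place of trifluoromethyl, or an alkyl chain in place of the whole aryl group, would give a step beyond the scatter remains open.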